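One Exchange on a Shared Core at the Cytotoxicity Limit

The source may report more compounds than this note shows. Statements on the series, on what has been measured and on what is new or still open speak of the compounds shown alone.

Compound 1, `[N-]=[N+]=N[C@H]1C[C@H](n2cnc3c(NCCO)nc(N)nc32)O[C@@H]1CO`: in an ADME assay on Vero cells (Chlorocebus sabaeus) for cytotoxicity, with a stated time of 5 days (a higher number here means a weaker inhibitor, a lower number a stronger inhibitor), compound 1 gives > 100000 nM, a limit of the assay rather than a number.
Compound 2, `COc1nc(NC2CC2)c2ncn([C@H]3C[C@H](N=[N+]=[N-])[C@@H](CO)O3)c2n1`: in this assay compound 2 gives > 100000 nM, again a limit.
Compound 3, `COc1nc(N)c2ncn([C@H]3C[C@H](N=[N+]=[N-])[C@@H](CO)O3)c2n1`: in this assay compound 3 gives > 100000 nM, also a limit.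

Going by the values given here, every value measured so far sits at the same limit (the limit of > 100000 nM in this assay, at which 3 of the 3 values shown sit). Compound 2 therefore stands at that limit, and where it lies relative to the other two cannot be read. Among the compounds with values here, the one measured single change, a step that the two limits leave unreadable from compound 2 to compound 3, hydrogen in place of cyclopropyl on a nitrogen on an aromatic ring, is likewise unreadable, as both of its ends are limits.

Compound 4, `[N-]=[N+]=N[C@H]1C[C@H](n2cnc3c(NC4CC4)nc(N)nc32)O[C@@H]1CO`, differs from compound 2 by amino in place of methoxy on an aromatic carbon. Within the data shown here, no measured step bears on this exchange, and the only measured step has no readable size. The step that the limit leaves unreadable from compound 2 to compound 4 is therefore expected to be none beyond the scatter, with the measurement most likely ending at the limit once more. For compound 4 in this assay the estimate is 150000 nM, within a range from 50000 nM to 500000 nM.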

Compound 4, half-maximal inhibitory concentration: > 100000 nM
Compound 4 was reported as a limit; the forecaster's own chance of this, stated with the estimate: 85%; the middle value lies beyond the limit too.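

The steps linking compound 4 with compound 2 and compound 1 cannot be read, as all three compounds stand at a limit: the limit of > 100000 nM in this assay, at which 4 of the 4 values shown sit. The compounds shown leave open whether any exchange on the shared core alters the half-maximal inhibitory concentration in this assay at all.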